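The source may report more compounds than this note shows. Statements on the series, on what has been measured and on what is new or still open speak of the compounds shown alone.

Measured so far in a functional assay on SW 1116 cells (Homo sapiens) for cytotoxicity, read by MTT assay, with a stated time of 48 h; on this read-out higher numbers stand for weaker inhibition and lower numbers for stronger inhibition:
- compound 1 `O=C(CSc1nnc(-c2ccncc2)o1)N/N=C/c1ccc(F)cc1`: 15700 nM
- compound 2 `O=C(CSc1nnc(-c2ccncc2)o1)N/N=C/c1ccc(Br)cc1`: 21300 nM
- compound 3 `COc1ccc(/C=N/NC(=O)CSc2nnc(-c3ccncc3)o2)cc1`: 20300 nM

Compound 3 sits second highest of the three numbers, yet all three lie within the scatter of one another: a 1.4-fold higher number from compound 1 to compound 2 (0.13 log units; within the scatter), a 1.3-fold higher number from compound 1 to compound 3 (0.11 log units; within the scatter) and a 1.0-fold lower number from compound 2 to compound 3 (0.02 log units; within the scatter). Nothing separates the three on this assay.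

Compound 4 `O=C(CSc1nnc(-c2ccncc2)o1)N/N=C/c1ccccc1O` is not yet measured. It differs from compound 3 in one place: 2-hydroxyphenyl in place of 4-methoxyphenyl on a carbon with a double bond to nitrogen. Within the data shown here, the measured steps all swap one group for another on the same aromatic ring and none moved the number beyond the scatter, so they bear on this step only loosely; no measured pair exchanges a methoxy for a hydroxy or shifts where the group sits. On that basis compound 4 is expected to stay close to compound 3, with the step of a 1.1-fold lower number from compound 3 to compound 4 (0.05 log units; within the scatter) estimated as nothing beyond the scatter. Compound 4 is estimated at 18000 nM, within 7000 nM to 45000 nM.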

Compound 4, half-maximal inhibitory concentration: 7380 nM
Compound 4: middle estimate off by 2.4-fold (0.39 log units), on the high side, and the stated range covers the measured number.
By their numbers in this assay, from the lowest: compound 4; then compounds 1, 3 and 2 (each within the scatter of the next).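

In this assay, among these compounds, 2-hydroxyphenyl gives the first changes beyond the scatter: a 2.8-fold lower number from compound 3 to compound 4 (0.44 log units; beyond the scatter), a 2.9-fold lower number from compound 2 to compound 4 (0.46 log units; beyond the scatter) and a 2.1-fold lower number from compound 1 to compound 4 (0.33 log units; beyond the scatter), all modest. Exchanges among 4-fluorophenyl, 4-bromophenyl and 4-methoxyphenyl moved nothing beyond the scatter, so this position is not insensitive to the group it carries. Nothing at hand explains the step.

From the compounds shown here alone, the step changes the group and its place on the ring together, so which of the two matters stays open. Going by these compounds, how an amine or a carboxylic acid in place of the hydroxy would read also stays open.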